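Shortening a chain on an alkyne-bearing core

This account rests on a few compounds, and the source may have more. Where it says the series, first, only, none or still open, it means among the compounds named here.

Measured so far:
compound 1, `CCCCCCCCCCCc1cc2cn(COCCO)c(=O)nc2o1`, 132000 nM
compound 2, `CCCCCCCc1cc2cn(COCCO)c(=O)nc2o1`, 140000 nM
compound 3, `CCCCCCCCC#Cc1cc2cn(COCCO)c(=O)nc2o1`, 42000 nM

All three were tested in a functional assay on HEL cells (Homo sapiens); a lower number here means that less compound is tolerated, a higher number that more compound is tolerated. Compound 1 and compound 2 share a core and differ only by hydrogen in place of butyl on a saturated chain carbon, seven bonds along the chain from an aromatic carbon. The step of a 1.1-fold higher number from compound 1 to compound 2 (0.03 log units; within the scatter) shows that removing the butyl here left the tolerated concentration essentially unchanged. Compound 3 carries a different core; how the two cores differ is not broken down here. Its value stands lowest of the three, and its gaps to compound 1 and to compound 2 both lie beyond the scatter, so compound 3 is tolerated least.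

Compound 4, `CCCCC#Cc1cc2cn(COCCO)c(=O)nc2o1`, has not yet been measured. It is made from compound 3 by hydrogen in place of butyl on a saturated chain carbon, four bonds along the chain from a triple-bonded carbon. This is the same kind of change as that from compound 1 to compound 2, though the place differs: there the carbon lay seven bonds along the chain from an aromatic carbon, here four bonds along the chain from a triple-bonded carbon. Because a 1.1-fold higher number from compound 1 to compound 2 (0.03 log units; within the scatter) was within the scatter, the expectation is that the step from compound 3 to compound 4 will likewise be small, estimated as a 1.1-fold higher number from compound 3 to compound 4 (0.06 log units; within the scatter). The estimated value of compound 4 in this assay is 48000 nM, with an expected range from 20000 nM to 120000 nM.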

Compound 4, half-maximal cytotoxic concentration: > 50000 nM
Compound 4 was reported as a limit; the forecaster's own chance of this, stated with the estimate: 10%; at least 1.0-fold (0.01 log units) between middle value and limit.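

In this assay compound 4 gives > 50000 nM, which is a limit of the assay and not a number. Putting hydrogen in place of butyl on the alkyne-bearing core gives an at least 1.1-fold higher number from compound 3 to compound 4 (0.07 log units; that floor lies within the scatter), and setting this beside the same change on the other core allows only a partial comparison: the same change on two cores in this assay, a 1.1-fold higher number (0.03 log units; within the scatter) from compound 1 to compound 2 and an at least 1.1-fold higher number (0.07 log units; that floor lies within the scatter) from compound 3 to compound 4; the limit leaves it open whether they differ The result fits a change that stays small on both cores, but it does not establish this, as the true size of the step on the alkyne-bearing core may be much larger than its floor, and the step from compound 2 to compound 4 cannot be read at all.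

The compounds shown leave open where the true value of compound 4 lies and whether the same shortening of the chain would behave alike on any further core. They also leave open how well cells would tolerate either core if its chain ended in an amine or a carboxylic acid rather than in plain carbon and hydrogen.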